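Methoxy added to the benzenesulfonamide ring of compound 2

The compounds below may be only part of what the source reports. "The series", "measured", "known", "first", "only" and "open" are said of these compounds alone.

Measured in a functional assay on THP-1 cells (Homo sapiens) for antiproliferative activity, tested at 20 uM; a higher number here means a stronger effect of the compound at the concentration tested, a lower number a weaker effect:
- compound 1 `COC(=O)c1ccc(CS(=O)(=O)Nc2ccc3c(c2)cc(C)c(=O)n3C)cc1` gives 9%
- compound 2 `Cc1cc2cc(NS(=O)(=O)Cc3ccc(C(=O)NO)cc3)ccc2n(C)c1=O` gives 8%

Compound 2 and compound 1 lie within the scatter of each other, as the change a number 1 percentage points lower from compound 1 to compound 2 (within the scatter) shows; both numbers are small, and compound 2 has the lower of the two but not by more than the usual scatter. Compound 3 `COc1cc(C(=O)NO)ccc1CS(=O)(=O)Nc1ccc2c(c1)cc(C)c(=O)n2C` is not yet measured. It differs from compound 2 in one place: methoxy in place of hydrogen on an aromatic carbon. Within the data shown here, no measured step concerns such a change; the only step known, from the ester to the hydroxamic acid, left this assay unchanged, and nothing here points to a large effect of the methoxy group. For compound 3 the expected step is therefore a number 2 percentage points higher from compound 2 to compound 3 (within the scatter), which is no step beyond the scatter. Compound 3 is estimated at 10%, within 0% to 25%.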

Compound 3, a percentage reported as inhibition, at one concentration (the size of the read-out at that concentration, not a potency): 0%
Compound 3: the middle estimate sits 10 percentage points above what was measured; measured number inside the range.
By their numbers in this assay, from the lowest: compounds 3, 2 and 1 (each within the scatter of the next).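

In this assay, methoxy in place of hydrogen on an aromatic carbon, ortho to a large group and meta to a hydroxycarbamoyl group, gives a number 8 percentage points lower from compound 2 to compound 3 (within the scatter). Among these compounds, this is the first look at a substituent on this ring, and it shows that adding methoxy at this position produces no effect beyond the scatter, so the hydroxamic acid compounds 2 and 3 cannot be told apart here. No measured evidence bears on why this is so.

On these data alone, it remains open whether an amine, a hydroxyl or a chlorine on the same aromatic carbon would give a step beyond the scatter. As far as these compounds go, it is also open whether methoxy on another carbon of this ring would do so, since this single position and single concentration say nothing about the rest of the ring.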